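The compounds below may be only part of what the source reports. "The series", "measured", "known", "first", "only" and "open" are said of these compounds alone.

In an ADME assay on HEK-293T cells (Homo sapiens) for cytotoxicity, read by MTT assay, with a stated time of 24 h (on this read-out lower numbers stand for higher toxicity in this test and higher numbers for lower toxicity in this test), compound 1 (`Cc1ccc(-c2nn(-c3ccccc3)cc2-c2nc3ccccc3[nH]2)cc1`) gives 187000 nM and compound 2 (`COc1ccc(S(=O)(=O)n2c(-c3cn(-c4ccccc4)nc3-c3ccc(F)cc3)nc3ccccc32)cc1`) gives 37300 nM as the lower of the two numbers. Compound 3 (`O=S(=O)(c1ccc(C(F)(F)F)cc1)n1c(-c2cn(-c3ccccc3)nc2-c2ccc(F)cc2)nc2ccccc21`) differs from compound 2 by having trifluoromethyl in place of methoxy on an aromatic carbon, para to a large group. Going by the values given here, no measured pair of compounds shows this change, so the data offer no direct guide, and no shift beyond the scatter is expected in this assay in either direction. The expected 1.1-fold lower number from compound 2 to compound 3 (0.03 log units; within the scatter) stays within that scatter. Compound 3 is estimated at 35000 nM with 15000 nM to 80000 nM as the expected range.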

Compound 3, half-maximal cytotoxic concentration: 241000 nM
Beside the measured number, compound 3's estimate is 6.9-fold (0.84 log units) below it, outside the stated range (above it).
By their numbers in this assay, from the lowest: compound 2; then compounds 1 and 3 (each within the scatter of the next).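

In this assay, going by these compounds alone, the change from 4-methoxyphenyl to 4-(trifluoromethyl)phenyl brings a 6.5-fold higher number from compound 2 to compound 3 (0.81 log units; beyond the scatter) and is the first change in a single place seen. It shows that this position, para to a large group, can move the read-out towards lower toxicity in this test. No measured evidence accounts for the size or direction of this step. Still open, from the compounds shown here alone, is whether an amine, a carboxylic acid or a chlorine atom at this position would move the number the same way, and whether a single pair is a reliable guide.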